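This account rests on a few compounds, and the source may have more. Where it says the series, first, only, none or still open, it means among the compounds named here.

Compound 3, `CCCc1c(COc2ccc(C(=O)CCCC(=O)O)cc2)ccc(C(C)=O)c1O`, carries a carboxylic acid at the end of the chain on the shared core. In a functional assay on ileum (Cavia porcellus) with cysteinyl leukotriene receptor (Homo sapiens) as the target (a lower number here means a less potent compound, a higher number a more potent compound, by a factor of ten per unit of this negative logarithm), compound 3 gives 6.81, the lowest of the three numbers measured. Compound 1, `CCCc1c(COc2ccc(C(=O)CCc3nnn[nH]3)cc2)ccc(C(C)=O)c1O`, gives 7.09, and compound 2, `CCCc1c(COc2ccc(C(=O)C(C)Cc3nnn[nH]3)cc2)ccc(C(C)=O)c1O`, gives 7.18. The step of a number 0.28 log units lower from compound 1 to compound 3 (within the scatter) shows that swapping a tetrazole for a carboxylic acid at the chain end hardly moved the number, while a number 0.37 log units lower from compound 2 to compound 3 (beyond the scatter) was a modest drop when the chain was also simplified.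

Compound 4, `CCCc1c(COc2ccc(C(=O)CCCCc3nnn[nH]3)cc2)ccc(C(C)=O)c1O`, differs from compound 3 by the change ((1H-tetrazol-5-yl)methyl in place of carboxy on a saturated chain carbon, three bonds along the chain from a carbonyl carbon). This returns the tetrazole ring of compound 1 and compound 2 while lengthening the chain by one carbon. Since a number 0.28 log units lower from compound 1 to compound 3 (within the scatter) was small, the reverse direction is expected to be small as well, perhaps recovering a little potency. Compound 4 is therefore expected to give 7, within 6.5 to 7.5, which means an expected step of a number 0.19 log units higher from compound 3 to compound 4 (within the scatter).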

Compound 4, negative logarithm of the antagonist equilibrium constant: 7.28
Compound 4: middle estimate off by 0.28 log units, on the low side; the range from low to high includes it.
By their numbers in this assay, from the lowest: compounds 3, 1, 2 and 4 (each within the scatter of the next, the first and the last beyond it).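

Going by these compounds alone, replacing carboxy with (1H-tetrazol-5-yl)methyl, on a saturated chain carbon three bonds along the chain from a carbonyl carbon, gives a number 0.47 log units higher from compound 3 to compound 4 (beyond the scatter) in this assay and is the first step here in which a tetrazole compound stands clear of the acid at a matching unbranched chain. Among the tetrazole compounds, a number 0.19 log units higher from compound 1 to compound 4 (within the scatter) and a number 0.10 log units higher from compound 2 to compound 4 (within the scatter) show that the 4-(1H-tetrazol-5-yl)butyl chain can be told apart from neither of the shorter or branched chains. Nothing available explains the difference between the tetrazole and the acid.

On these data alone, how much of the step from the acid belongs to the ring and how much to the extra chain carbon remains open, and a 4-carboxybutyl group on the same carbonyl carbon would separate the two. As far as these compounds go, how a still longer tetrazole chain or an amine at the chain end would read also remains open.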